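Pyridine amidrazone thiosemicarbazides: cyclic amine variation

This account rests on a few compounds, and the source may have more. Where it says the series, first, only, none or still open, it means among the compounds named here.

Measured so far in a functional assay on MCF7 cells (Homo sapiens) for cytotoxicity, read by MTT assay, with a stated time of 72 h, tested at 100 uM; a higher number here means more inhibition of growth at the concentration tested, a lower number less inhibition of growth:
compound 1 `N/C(=N\NC(=S)N1CCCCCC1)c1ccccn1` gives 84%
compound 2 `N/C(=N\NC(=S)N1CCOCC1)c1ccccn1` gives 81.6%
compound 3 `Cc1ccnc(/C(N)=N/NC(=S)N2CCOCC2)c1` gives 12.8%

Compound 2 stands second highest of the three numbers in this assay; compound 1 sits within the scatter of it, so the two cannot be ordered, while compound 3 lies far lower. Among the measured compounds shown here, the only step between measured compounds that differ in one place is that from compound 2 to compound 3, a methyl in place of hydrogen on an aromatic carbon, which gave a number 68.8 percentage points lower from compound 2 to compound 3 (beyond the scatter).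

Compound 4 `N/C(=N\NC(=S)N1CCCCC1)c1ccccn1` is still to be measured. It differs from compound 2 by piperidin-1-yl in place of morpholin-4-yl on a thiocarbonyl carbon. For the measured compounds named here, no measured step varies this position directly; the change from compound 2 to compound 3 concerns the aromatic ring and does not bear on it. Compound 1 differs from compound 2 only in the ring on the thiocarbonyl carbon, and its value sits within the scatter of compound 2, which is the closest guide available. A step within the scatter is therefore expected for compound 4 in this assay, with no clear direction, so that the estimated step is a number 0.4 percentage points higher from compound 2 to compound 4 (within the scatter). Compound 4 is expected to give about 82%, in the range 68% to 92%.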

Compound 4, percent growth inhibition at one concentration: 77.7%
Compound 4: the middle estimate sits 4.3 percentage points above what was measured; measured number inside the range.
By their numbers in this assay, from the lowest: compound 3; then compounds 4, 2 and 1 (each within the scatter of the next).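

In this assay, among the compounds shown here, the exchange of morpholin-4-yl for piperidin-1-yl on the thiocarbonyl carbon gives the first direct reading of this position between two six-membered rings, with a number 3.9 percentage points lower from compound 2 to compound 4 (within the scatter). Removing the ring oxygen therefore produces no change that can be told from the scatter, and by their numbers compounds 4, 2 and 1 form a run in which each lies within the scatter of the next, so no order can be drawn among them. The measurements offer no explanation for how little this exchange alters the read-out.

Still open, as far as these compounds go, is whether the position accepts groups of another kind, such as an open-chain dimethylamino group or a piperazin-1-yl ring bearing a free ring amine, or whether the tolerance holds only for the saturated rings seen so far. Also open, from the compounds shown here alone, is whether the large loss seen with the aromatic methyl, a number 68.8 percentage points lower from compound 2 to compound 3 (beyond the scatter), recurs when piperidin-1-yl rather than morpholin-4-yl sits on the thiocarbonyl carbon.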